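Shortening the chain on a shared core: compound 2 to compound 3

The source may hold more compounds than are shown below. What is called first, only, known or untested is meant among the compounds shown, and "the series" means these compounds.

Measured so far:
- compound 1, `Nc1ccccc1Nc1n[n+]([O-])c2ccccc2[n+]1[O-]`: 16100 nM
- compound 2, `CCCCCCCCNc1n[n+]([O-])c2ccccc2[n+]1[O-]`: 18200 nM

Two compounds share one core and differ only in the group attached to its ring nitrogen. In a functional assay on PC-3 cells (Homo sapiens) for cytotoxicity, read by MTT assay, with a stated time of 48 h (on this read-out higher numbers stand for weaker inhibition and lower numbers for stronger inhibition), compound 1 gives 16100 nM, and in the same assay compound 2 gives 18200 nM. Compound 2 carries the highest of the two numbers, but its nearest neighbour is compound 1, and the gap between the two lies within the scatter, so the two results cannot be told apart.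

Compound 3, `[O-][n+]1nc(NCCO)[n+]([O-])c2ccccc21`, has not been tested yet. Compared with compound 2, the change is hydroxy in place of hexyl on a saturated chain carbon, two bonds along the chain from a nitrogen on an aromatic ring. The chain is cut back and ends in a hydroxy group, with the core and its ring nitrogen left unchanged.

No measured pair here isolates this kind of change, so there is no shown step to lean on. Given that compound 2 gives 18200 nM, a modest step toward a higher number is expected for compound 3, a 1.5-fold higher number from compound 2 to compound 3 (0.19 log units; within the scatter), though a result within the scatter would not surprise. For compound 3 the estimate is 28000 nM, with a range from 9000 nM to 90000 nM.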

Compound 3, half-maximal inhibitory concentration: 22400 nM
Compound 3: the middle estimate sits 1.3-fold (0.10 log units) above what was measured; the range from low to high includes it.
By their numbers in this assay, from the lowest: compounds 1, 2 and 3 (each within the scatter of the next).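

In this assay, replacing hexyl with hydroxy on a saturated chain carbon, two bonds along the chain from a nitrogen on an aromatic ring, gives a 1.2-fold higher number from compound 2 to compound 3 (0.09 log units; within the scatter) and so cannot be told apart from no effect. Going by these compounds alone, this is the first direct comparison at this position, since compound 1 and compound 2 differ by more than this one kind of change and no step links them. Here the hexyl group, with its 6 carbon atoms and no hydrogen-bond donor or acceptor, gives way to a single oxygen that counts as one donor and one acceptor, and even an exchange this large leaves no detectable difference in the read-out, although nothing measured here offers an explanation for this result.

As far as these compounds go, it remains open whether any group at this place can shift the number beyond the scatter, for example an amine or a carboxylic acid in place of hydroxy. From the compounds shown here alone, because a single step says little about a whole series, it also remains open whether a methoxy group there would behave like hydroxy or whether the same exchange would look alike on a different core.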